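Aryl-to-phenoxy swap at the ring carbon of compound 2

The source may report more compounds than this note shows. Statements on the series, on what has been measured and on what is new or still open speak of the compounds shown alone.

Going by the values given here, compound 2 `CCOC(=O)c1cnc(-c2cnc3ccccc3c2)nc1NN1C(=O)C=C(C)C1=O` gives 6000 nM in a functional assay on Jurkat cells for inhibition of nuclear factor NF-kappa-B complex (Homo sapiens) (on this read-out higher numbers stand for weaker inhibition and lower numbers for stronger inhibition), the highest of the three numbers so far. Compound 1 `CCOC(=O)c1cnc(-c2cc(Cl)nc(Cl)c2)nc1NN1C(=O)C=C(C)C1=O` gives 2000 nM in this assay, and compound 3 `CCOC(=O)c1cnc(-c2cccc(OC)c2)nc1NN1C(=O)C=C(C)C1=O` gives 5000 nM. The two direct comparisons involving compound 2 run in opposite senses: a 3.0-fold higher number from compound 1 to compound 2 (0.48 log units; beyond the scatter), whereas a 1.2-fold lower number from compound 2 to compound 3 (0.08 log units; within the scatter). Alongside, a 2.5-fold higher number from compound 1 to compound 3 (0.40 log units; beyond the scatter).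

Compound 4 `CCOC(=O)c1cnc(Oc2ccccc2)nc1NN1C(=O)C=C(C)C1=O` is the next compound, differing from compound 2 in one place: phenoxy in place of quinolin-3-yl on an aromatic carbon. Both measured steps away from compound 1 exchanged one directly attached aromatic group for another and cost a modest amount of inhibition; the step between compound 2 and compound 3 exchanged two such groups with no change beyond the scatter. Among the compounds with values here, none of the measured steps introduces an oxygen-linked group at this aromatic carbon, so the change in compound 4 is of a kind not yet covered by the series.

Given that the three aromatic variants span only a narrow window, the expectation is for a small step of a 1.5-fold higher number from compound 2 to compound 4 (0.18 log units; within the scatter), tending toward a higher number. In this assay compound 4 is estimated at 9000 nM, with an expected range from 3000 nM to 30000 nM, the upper end reflecting the untested nature of the oxygen linkage.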

Compound 4, half-maximal inhibitory concentration: 15000 nM
Beside the measured number, compound 4's estimate is 1.7-fold (0.22 log units) below it; the range from low to high includes it.
By their numbers in this assay, from the lowest: compound 1; then compounds 3 and 2 (each within the scatter of the next); then compound 4.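

At the aromatic carbon between two ring nitrogen atoms, phenoxy is the only oxygen-linked group among the compounds shown, and in this assay it lies beyond the scatter from all three directly attached aromatic groups (a 2.5-fold higher number from compound 2 to compound 4 (0.40 log units; beyond the scatter); a 3.0-fold higher number from compound 3 to compound 4 (0.48 log units; beyond the scatter); a 7.5-fold higher number from compound 1 to compound 4 (0.88 log units; beyond the scatter)). Compound 4 is therefore the weakest inhibitor of the four, and its steps from compound 2 and compound 3 exceed the step between those two, which stays within the scatter, so this position does respond to the exchange of a directly attached aromatic group for phenoxy. Phenoxy differs from quinolin-3-yl in both its linking atom and its ring system, and the available data offer no measurement that explains the loss or separates those two changes.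

A directly attached unsubstituted phenyl group would help separate the effect of the oxygen linkage from that of the aromatic group itself, while anilino and phenylthio would test other linking atoms at the same carbon. Going by these compounds, whether 3-methoxyphenoxy or 3,5-dichlorophenoxy would follow the order seen among the directly attached groups also remains open.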